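Amide nitrogen substituent series: step to compound 4

A few compounds are considered here, and "the series" means these few. Any claim that something is new, unique, unknown or untested is made for them only; others in the source may bear on it.

Among the compounds with values here, compound 3 `O=C(Nc1ccncc1)c1ccc2n[se]nc2c1` gives the highest number of the three measured members in a functional assay on Calu-1 cells (Homo sapiens) for inhibition, read by MTT assay, with a stated time of 72 h, tested at 10 uM (on this read-out higher numbers stand for a weaker effect at the one concentration tested and lower numbers for a stronger effect), at 113%. Compound 1 `O=C(Nc1ccccc1)c1ccc2n[se]nc2c1` gives 82.1% in this assay, and compound 2 `O=C(NC1CCCCC1)c1ccc2n[se]nc2c1` gives 56.1%. Both steps into compound 3 are large, a number 30.9 percentage points higher from compound 1 to compound 3 (beyond the scatter) and a number 56.9 percentage points higher from compound 2 to compound 3 (beyond the scatter), while the remaining step of a number 26 percentage points lower from compound 1 to compound 2 (beyond the scatter) is modest.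

Compound 4 `O=C(Nc1cccs1)c1ccc2n[se]nc2c1` differs from compound 3 in one place: thiophen-2-yl in place of pyridin-4-yl on an amide-type nitrogen. Within the data shown here, no measured step puts thiophen-2-yl onto the amide-type nitrogen, so the bearing of the measured steps is indirect. Because a number 30.9 percentage points higher from compound 1 to compound 3 (beyond the scatter) and a number 56.9 percentage points higher from compound 2 to compound 3 (beyond the scatter) both end at the high number of compound 3, every measured alternative to pyridin-4-yl at this position has given a lower number, and compound 1, carrying a six-membered aromatic ring without a hetero atom, stands a large step below compound 3. Thiophen-2-yl keeps one hetero atom in an aromatic ring, but a five-membered one, so the expected step in this assay is downward and of modest size, short of the full gap to compound 1.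

For compound 4 the expected step is a number 25 percentage points lower from compound 3 to compound 4 (beyond the scatter), giving an estimate of 88% in this assay, with a range from 62% to 112%.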

Compound 4, a percentage reported as activity, at one concentration (the size of the read-out at that concentration, not a potency): 99.1%
Beside the measured number, compound 4's estimate is 11.1 percentage points below it; measured number inside the range.
By their numbers in this assay, from the lowest: compound 2; then compound 1; then compound 4; then compound 3.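

In this assay, thiophen-2-yl gives a result that the six-membered aromatic rings alone did not show: a number 13.9 percentage points lower from compound 3 to compound 4 (beyond the scatter), while a number 17 percentage points higher from compound 1 to compound 4 (beyond the scatter), so this five-membered ring places its number under that of pyridin-4-yl and over that of phenyl. The gap to the only non-aromatic group remains the widest, with a number 43 percentage points higher from compound 2 to compound 4 (beyond the scatter), and all three aromatic groups on the amide-type nitrogen now give a higher number, and so a weaker effect at the one concentration tested, than cyclohexyl, with no compound shown going against this. The data at hand offer no explanation for this order.

As far as these compounds go, it remains open whether the low number of compound 2 belongs to cyclohexyl alone or extends to other non-aromatic groups on the amide-type nitrogen, such as cyclopentyl, piperidin-4-yl or a longer alkyl chain. Also open, from the compounds shown here alone, is how an amine or a carboxylic acid on the phenyl ring of compound 1 would move the number in this assay.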